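Swapping the side chain of compound 1 for compound 3

The compounds below may be only part of what the source reports. "The series", "measured", "known", "first", "only" and "open" are said of these compounds alone.

In a functional assay for inhibition, with Homo sapiens as the target (on this read-out lower numbers stand for stronger inhibition and higher numbers for weaker inhibition), compound 1 `C[C@H](CC(=O)O)NC(=O)CN1CCc2ccc(N3CCNCC3)cc2C1=O` gives 30 nM and compound 2 `O=C(O)C[C@H](NC(=O)CN1CCc2ccc(N3CCNCC3)cc2C1=O)C1=CC=CN(O)C1` gives 18 nM. Within the data shown here, these two values lie within the usual scatter of each other, so compound 1 cannot be ranked against its only neighbour. Compound 3 `N[C@@H](CNC(=O)CN1CCc2ccc(N3CCNCC3)cc2C1=O)C(=O)O` keeps the core of compound 1 but changes the group on an amide-type nitrogen: 2-amino-2-carboxyethyl in place of 1-(carboxymethyl)ethyl on an amide-type nitrogen. In words, 2-amino-2-carboxyethyl stands in place of 1-(carboxymethyl)ethyl, so an amino group appears that neither measured compound carries.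

Among the measured compounds shown here, only one measured step bears on this, and only loosely: a 1.7-fold lower number from compound 1 to compound 2 (0.22 log units; within the scatter). It shows that compound 2 stays level with compound 1 after a large addition to this side chain, yet it says nothing about an added amino group. With so little evidence, a modest loss is a cautious guess rather than a firm trend. The expected change is a 2.0-fold higher number from compound 1 to compound 3 (0.30 log units; within the scatter), towards weaker inhibition, and a result within the scatter would be no surprise. For compound 3 the estimated value in this assay is 60 nM, with an expected range from 15 nM to 250 nM.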

Compound 3, half-maximal inhibitory concentration: 630 nM
Compound 3: the middle estimate sits 11-fold (1.02 log units) below what was measured, and the stated range ends below it.
By their numbers in this assay, from the lowest: compounds 2 and 1 (each within the scatter of the next); then compound 3.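

In this assay, the side chain on the amide-type nitrogen turns out to matter a great deal: a 21-fold higher number from compound 1 to compound 3 (1.32 log units; beyond the scatter) is a large step towards weaker inhibition. The earlier pair gave no warning of this, as a 1.7-fold lower number from compound 1 to compound 2 (0.22 log units; within the scatter) stayed within the scatter even though that change added a whole ring to the chain, whereas here 1-(carboxymethyl)ethyl and 2-amino-2-carboxyethyl each carry the same number of heavy atoms and the read-out still moves far, so among these compounds the number of atoms added does not track the size of the step. Nothing shown here explains why this swap costs so much.

The swap also changes two things at once, bringing in an amino group and rearranging the chain that carries the carboxylic acid, and the compounds shown cannot separate these two parts. A plain 2-carboxyethyl group on the same nitrogen, with the chain of compound 3 but no amine, would show how much of the step belongs to the amino group and how much to the chain itself.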